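Swapping the aryl group on the saturated ring carbon

The source may hold more compounds than are shown below. What is called first, only, known or untested is meant among the compounds shown, and "the series" means these compounds.

Compound 3 `CN(C)c1ccc(C2C(C#N)=C(N)OC(c3c[nH]c4ccccc34)=C2C#N)cc1` gives 26.7% in a functional assay, tested at 400 ug/mL (on this read-out lower numbers stand for a weaker effect and higher numbers for a stronger effect at the one concentration tested), the lowest of two numbers, with compound 2 `COc1ccc(C2C(C#N)=C(N)OC(c3c[nH]c4ccccc34)=C2C#N)cc1OC` nearest at 28.1%. Compound 1 `N#CC1=C(N)OC(c2c[nH]c3ccccc23)=C(C#N)C1c1ccc2ccccc2c1` was reported as "not active" (no number reported) in this assay, without a number. Among the measured compounds shown here, the one measured step that bears here, a number 1.4 percentage points lower from compound 2 to compound 3 (within the scatter), shows that exchanging one aryl group for another on this carbon moved the read-out little. Compound 4 `Cc1ccccc1C1C(C#N)=C(N)OC(c2c[nH]c3ccccc23)=C1C#N` differs from compound 3 by 2-methylphenyl in place of 4-(dimethylamino)phenyl on a saturated ring carbon. A shift of similar size is therefore expected, with some chance of no activity as seen for compound 1, so compound 4 is expected to show a number 4.7 percentage points lower from compound 3 to compound 4 (within the scatter). Compound 4 is estimated at 22%, within 5% to 35%.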

Compound 4, a percentage reported as activity, at one concentration (the size of the read-out at that concentration, not a potency): 25.7%
For compound 4 the middle estimate is 3.7 percentage points below the measured one; low and high end bracket the measured number.
By their numbers in this assay, from the lowest: compounds 4, 3 and 2 (each within the scatter of the next).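

On this assay, 2-methylphenyl gives a number 1 percentage points lower from compound 3 to compound 4 (within the scatter) and a number 2.4 percentage points lower from compound 2 to compound 4 (within the scatter). This aryl group is built of carbon only, so across compounds 2, 3 and 4, nitrogen or oxygen on the aryl group is not needed to hold this level of read-out. Nothing available explains why these three compounds read alike.

It remains open why the aryl group of compound 1 gives no reported number. Also open, as far as these compounds go, is how a carboxylic acid on the phenyl ring, or an amine in place of the aryl group, would read.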